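Anilino-linked analogues in a rat paw edema assay

The source may hold more compounds than are shown below. What is called first, only, known or untested is meant among the compounds shown, and "the series" means these compounds.

Measured compounds:
- compound 1, `Clc1ccc(-c2nnc(COc3ccc(-c4ccccc4)cc3)o2)cc1`, 75%
- compound 2, `Clc1ccc(Nc2nnc(COc3ccc(-c4ccccc4)cc3)s2)cc1`, 52.3%

In a functional assay on the whole organism (strain Wistar) for inhibition, with Rattus norvegicus as the target, read by paw edema, with a stated time of 3 h, at a dose of 10 mg/kg by the oral route (a higher number here means more inhibition at the dose given (going by the name of the read-out), a lower number less inhibition), compound 1 gives 75%, and compound 2 gives 52.3%. Of the two numbers, compound 2 stands lowest, and the gap to compound 1 lies beyond the scatter of the method.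

Compound 3, `Cc1ccc(Nc2nnc(COc3ccc(-c4ccccc4)cc3)s2)c(C)c1`, has not yet been measured. It differs from compound 2 in one place: 2,4-dimethylphenyl in place of 4-chlorophenyl on a nitrogen on an aromatic ring. Among the measured compounds shown here, no pair of measured compounds shows what such a change does, so the expectation can rest only on compound 2 itself. Nothing in the data points to a shift in either direction; the step is expected to stay within the scatter, and the step of a number 2.3 percentage points lower from compound 2 to compound 3 (within the scatter) is therefore estimated as small. Compound 3 is expected to give about 50% in this assay, within a range from 35% to 65%.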

Compound 3, a percentage reported as inhibition, in the whole organism at one dose (the size of the read-out at that dose, not a potency): 56.8%
Estimate against measurement, compound 3: 6.8 percentage points below; low and high end bracket the measured number.
By their numbers in this assay, from the lowest: compounds 2 and 3 (each within the scatter of the next); then compound 1.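

In this assay, the exchange of 4-chlorophenyl for 2,4-dimethylphenyl on a nitrogen on an aromatic ring gives a number 4.5 percentage points higher from compound 2 to compound 3 (within the scatter). Among the compounds shown here, this is the first pair that differs in one place, and it shows that this position accepts a ring carrying two methyl groups in place of one carrying chlorine without a change that can be told from the scatter of the method. Nothing at hand bears on why the two groups read alike.

For the compounds shown here, the pair covers only two substituted phenyl groups, so it remains open whether an unsubstituted phenyl, a cyclohexyl group or a ring carrying a carboxylic acid would be accepted on that nitrogen in the same way. With a single oral dose and a single time point, the numbers also leave open how the two compounds would compare at other doses.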